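The compounds below may be only part of what the source reports. "The series", "measured", "known", "first", "only" and "open" are said of these compounds alone.

Measured so far: compound 1 `Cc1cccc(Nc2nc(C)c(C(=O)/C=C/c3ccccc3Cl)s2)c1` gives 24200 nM in a functional assay on BGC-823 cells (Homo sapiens) for cytotoxicity, read by MTT assay; on this read-out lower numbers stand for stronger inhibition and higher numbers for weaker inhibition. Compound 2 `Cc1nc(Nc2ccc(Cl)c(Cl)c2)sc1C(=O)/C=C/c1ccccc1` gives 10600 nM in this assay. Compound 3 `Cc1ccccc1Nc1nc(C)c(C(=O)/C=C/c2ccccc2)s1` gives > 25000 nM in this assay, which is a limit of the assay and not a measured number.

Compound 3 therefore stands at the weak end of what has been measured, at the limit (the limit of > 25000 nM in this assay, at which 1 of the 3 values shown sits). For the measured compounds named here, the only measured step that touches it, an at least 2.3-fold higher number from compound 2 to compound 3 (0.37 log units; beyond the scatter), shows that exchanging the 3,4-dichlorophenyl group for 2-methylphenyl made the number at least modestly higher, meaning weaker inhibition.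

Compound 4 `Cc1cccc(Nc2nc(C)c(C(=O)/C=C/c3ccccc3)s2)c1` differs from compound 3 by a single change: 3-methylphenyl in place of 2-methylphenyl on a nitrogen on an aromatic ring. Going by the values given here, no measured pair shows exactly this change on its own. Compound 1 carries the same 3-methylphenyl group, but it differs from compound 3 in a second place too, so only the two values can be set side by side: compound 1 gives 24200 nM. That number lies close to where compound 3 stands.

On that basis compound 4 is expected to remain near the limit, and the expected step that the limit leaves unreadable from compound 3 to compound 4 is none beyond the scatter. Compound 4 is estimated at 26000 nM, within a range from 11000 nM to 60000 nM.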

Compound 4, half-maximal inhibitory concentration: 13600 nM
For compound 4 the middle estimate is 1.9-fold (0.28 log units) above the measured one; the range from low to high includes it.
By their numbers in this assay, from the lowest: compounds 2, 4 and 1 (each within the scatter of the next, the first and the last beyond it). At a limit, above all of these: compound 3.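

The exchange of 2-methylphenyl for 3-methylphenyl on the nitrogen now has a pair of its own in this assay, which gives an at least 1.8-fold lower number from compound 3 to compound 4 (0.26 log units; that floor lies within the scatter). The value of compound 3 remains a limit and not a number, so the full size of this step cannot be read and it may be larger than its floor: the limit of > 25000 nM in this assay, at which 1 of the 4 values shown sits.

Compound 4 also shows that, among the groups on this nitrogen, 3-methylphenyl and 3,4-dichlorophenyl are not separated, with a 1.3-fold higher number from compound 2 to compound 4 (0.11 log units; within the scatter), and that hydrogen in place of chloro on the other aromatic ring makes no clear difference either, with a 1.8-fold lower number from compound 1 to compound 4 (0.25 log units; within the scatter).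

The compounds shown leave open how a plain phenyl, or a phenyl carrying a methoxy group, an amine or a carboxylic acid, would read on this nitrogen. They also leave open whether hydrogen and chloro on the other ring would still read alike with 2-methylphenyl or 3,4-dichlorophenyl on the nitrogen in place of 3-methylphenyl.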